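The source may hold more compounds than are shown below. What is called first, only, known or untested is meant among the compounds shown, and "the series" means these compounds.

In a functional assay on T98G cells (Homo sapiens) for inhibition, read by MTT assay, with a stated time of 72 h (on this read-out higher numbers stand for weaker inhibition and lower numbers for stronger inhibition), compound 1 (`CC1(C)CC(NC(=S)Nc2cccc(C#N)c2)c2cc(Br)ccc2O1`) gives 9000 nM, and compound 2 (`CC1(C)CC(NC(=S)Nc2ccc(C#N)cc2)c2cc(Br)ccc2O1`) gives 24000 nM. Compound 2 therefore holds the higher of the two numbers and is the weaker inhibitor of this pair. Compound 3 (`CC1(C)CC(NC(=S)Nc2ccccc2Cl)c2cc(Br)ccc2O1`) keeps the shared core but carries 2-chlorophenyl in place of 4-cyanophenyl on an amide-type nitrogen. Among the measured compounds shown here, only one measured step bears on this change: a 2.7-fold higher number from compound 1 to compound 2 (0.43 log units; beyond the scatter). It altered the group on that same nitrogen and was modest in size. For the measured compounds named here, no measured compound yet carries 2-chlorophenyl, so the data do not fix the direction of the new step. A step of similar or smaller size is expected in this assay, with a slight lean toward a lower number, since compound 2 stands at the high end and compound 1 sits at 9000 nM. The expected change is a 1.6-fold lower number from compound 2 to compound 3 (0.20 log units; within the scatter). For compound 3 the estimated value is 15000 nM, with an expected range from 6000 nM to 40000 nM.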

Compound 3, half-maximal inhibitory concentration: 8000 nM
The estimate for compound 3 lay 1.9-fold (0.27 log units) above the measured number, within the range that was stated.
By their numbers in this assay, from the lowest: compounds 3 and 1 (each within the scatter of the next); then compound 2.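

In this assay, the group on the amide-type nitrogen can now be seen to tolerate more than a shift of the nitrile: replacing 4-cyanophenyl with 2-chlorophenyl, a group with no nitrile at all, gives a 3.0-fold lower number from compound 2 to compound 3 (0.48 log units; beyond the scatter). Against 3-cyanophenyl, the same group gives a 1.1-fold lower number from compound 1 to compound 3 (0.05 log units; within the scatter), so compound 1 and compound 3 cannot be told apart here, while compound 2, with steps beyond the scatter to both, is the weakest inhibitor of the three and the nitrile is not needed to reach the level of compound 1. Nothing available explains why these three groups read as they do.

The compounds shown leave open whether moving the chlorine around the phenyl ring would change the number as moving the nitrile did in a 2.7-fold higher number from compound 1 to compound 2 (0.43 log units; beyond the scatter). They also leave open how a phenyl ring bearing an amine or a carboxylic acid, or a cyclohexyl group in place of the phenyl ring, would read on this nitrogen.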